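Sulfonamide nitrogen substituent on the shared core

The source may report more compounds than this note shows. Statements on the series, on what has been measured and on what is new or still open speak of the compounds shown alone.

Compound 1 `CC(C)OS(=O)(=O)c1ccc(F)c2ncc(I)cc12`: in an assay for inhibition of methylcytosine dioxygenase TET2 (Homo sapiens), read by mass spectrometry, with stated times of 30 min and 1 h (a lower number here means a stronger inhibitor, a higher number a weaker inhibitor), compound 1 gives > 200000 nM, which is a limit of the assay.
Compound 2 `O=S(=O)(Nc1ccccc1)c1ccc(F)c2ncc(I)cc12`: in this assay compound 2 gives 23900 nM.

Among the compounds with values here, compound 2 holds the only number in this assay; the other value is a limit (the limit of > 200000 nM in this assay, at which 1 of the 2 values shown sits). Compound 3 `O=S(=O)(NC1CCCCC1)c1ccc(F)c2ncc(I)cc12` differs from compound 2 by cyclohexyl in place of phenyl on a sulfonamide nitrogen. Within the data shown here, the single measured step, an at least 8.3-fold lower number from compound 1 to compound 2 (0.92 log units; beyond the scatter), alters the group on the sulfonyl sulfur, not the substituent on the sulfonamide nitrogen, so no measured step bears directly on this change. Compound 3 is expected near 30000 nM, between 8000 nM and 120000 nM. The expected step is a 1.3-fold higher number from compound 2 to compound 3 (0.10 log units; within the scatter), not beyond the scatter.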

Compound 3, half-maximal inhibitory concentration: > 200000 nM
Compound 3 ended at the assay's limit; the forecaster's own chance of this, stated with the estimate: 15%; middle value at least 6.6-fold (0.82 log units) from the limit.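

In this assay, within the data shown here, cyclohexyl in place of phenyl on a sulfonamide nitrogen gives an at least 8.3-fold higher number from compound 2 to compound 3 (0.92 log units; beyond the scatter), the first measured change at this substituent. With both rings made of six carbons, the aromatic phenyl ring, not ring size, separates the measurable compound from the one at the limit. Compound 3 is a limit, as is compound 1, so the step between them cannot be read: the limit of > 200000 nM in this assay, at which 2 of the 3 values shown sit.

As far as these compounds go, whether other aromatic rings on this nitrogen keep a measurable value stays open. A pyridyl, a methoxyphenyl or a benzyl group would address this.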